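The source may report more compounds than this note shows. Statements on the series, on what has been measured and on what is new or still open speak of the compounds shown alone.

Compound 3 `COc1ccc(C2=NN(C3=NC(=O)/C(=C4\C(=O)Nc5ccc(Br)cc54)S3)C(c3ccc(OC)cc3)C2)cc1` gives 410 nM in a functional assay on cells (Melanoma cell, Homo sapiens) for cytotoxicity, read by sulforhodamine B assay, with a stated time of 48 h (on this read-out higher numbers stand for weaker inhibition of growth and lower numbers for stronger inhibition of growth), the lowest of the three numbers in hand. Compound 1 `COc1ccc(C2CC(c3ccccc3)=NN2C2=NC(=O)/C(=C3\C(=O)Nc4ccc(Br)cc43)S2)cc1` gives 550 nM, which is within the scatter of compound 3, so no order can be drawn between them. Compound 2 `COc1ccc(C2=NN(C3=NC(=O)/C(=C4\C(=O)Nc5ccccc54)S3)C(c3ccc(OC)cc3)C2)cc1` gives 100000 nM, far weaker than either.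

Compound 4 `COc1ccc(C2=NN(C3=NC(=O)/C(=C4\C(=O)Nc5ccc(Cl)cc54)S3)C(c3ccc(OC)cc3)C2)cc1` differs from compound 3 by chloro in place of bromo on an aromatic carbon. Within the data shown here, no measured pair exchanges bromo for chloro, so the step has no direct precedent. The step from compound 1 to compound 3 a 1.3-fold lower number from compound 1 to compound 3 (0.13 log units; within the scatter) touches another part of the structure and says nothing about this one. The step from compound 2 to compound 3 a 240-fold lower number from compound 2 to compound 3 (2.39 log units; beyond the scatter) shows that the group on this aromatic carbon governs the read-out strongly, so the exchange cannot be dismissed as neutral, yet chloro is not hydrogen and a loss of that size is not the expectation.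

Compound 4 is therefore expected to give 800 nM, in the range 300 nM to 3000 nM. The expected step from compound 3 to compound 4 is a 2.0-fold higher number from compound 3 to compound 4 (0.29 log units; within the scatter), a modest weakening that may still fall within the scatter.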

Compound 4, concentration for total growth inhibition: 380 nM
Beside the measured number, compound 4's estimate is 2.1-fold (0.32 log units) above it; measured number inside the range.
By their numbers in this assay, from the lowest: compounds 4, 3 and 1 (each within the scatter of the next); then compound 2.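

In this assay, the exchange of bromo for chloro on this aromatic carbon leaves the read-out unresolved from the scatter: a 1.1-fold lower number from compound 3 to compound 4 (0.03 log units; within the scatter). Chloro also carries the large effect over hydrogen that had been seen only for bromo, a 260-fold lower number from compound 2 to compound 4 (2.42 log units; beyond the scatter), so in these compounds the effect does not depend on bromo specifically and either halogen supports it. Nothing available explains why the two halogens read alike.

On these data alone, whether this aromatic carbon accepts only a halogen remains open, since fluoro, a nitrile, an amine or a carboxylic acid there would test how far the effect over hydrogen extends. Also open, as far as these compounds go, is whether chloro behaves as bromo does on the core of compound 1, and whether the match between the two halogens holds in other cell types.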